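The source may report more compounds than this note shows. Statements on the series, on what has been measured and on what is new or still open speak of the compounds shown alone.

Working notes on the series.

Of the compounds shown here, three have been measured in a functional assay on U-87MG ATCC cells for antiproliferative activity against U-87 MG (Homo sapiens), read by MTT assay, with a stated time of 48 h, tested at 5 uM; a lower number here means a stronger effect, a higher number a weaker effect of the compound at the concentration tested. Compound 1 `Cc1nc(-c2ccc(Cl)cc2)sc1C(=O)CSc1nc(-c2ccccc2)c(C#N)c(=O)[nH]1` gives 88.9%. Compound 2 `COc1cccc(-c2nc(SCC(=O)c3sc(-c4ccccc4)nc3C)[nH]c(=O)c2C#N)c1` gives 99%. Compound 3 `Cc1nc(-c2ccccc2)sc1C(=O)CSc1nc(-c2ccc(Cl)c(Cl)c2)c(C#N)c(=O)[nH]1` gives 98.6%; its value lies within the scatter of compound 2 and within the scatter of compound 1, so no order among the three can be read from these numbers.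

The next member is compound 4 `Cc1nc(-c2ccccc2)sc1C(=O)CSc1nc(-c2ccccc2)c(C#N)c(=O)[nH]1`. Relative to compound 3 the change is phenyl in place of 3,4-dichlorophenyl on an aromatic carbon.

Going by the values given here, the only measured step touching this position is a number 0.4 percentage points lower from compound 2 to compound 3 (within the scatter), an exchange of one aryl group for another at the same place that left the read-out unchanged beyond the scatter. Compound 1 carries phenyl at this same position, though it differs elsewhere, and its value of 88.9% sits in the same band as the other two. Nothing measured points to a step beyond the scatter for the change to phenyl.

For compound 4 a value of 94% is expected, within 84% to 100%; the expected step is a number 4.6 percentage points lower from compound 3 to compound 4 (within the scatter).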

Compound 4, a percentage reported as activity, at one concentration (the size of the read-out at that concentration, not a potency): 92.1%
Compound 4: middle estimate off by 1.9 percentage points, on the high side; the range from low to high includes it.
By their numbers in this assay, from the lowest: compounds 1, 4, 3 and 2 (each within the scatter of the next, the first and the last beyond it).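

Phenyl now has a direct reading at this position, on the aromatic carbon next to the ring nitrogen, in this assay: the step of a number 6.5 percentage points lower from compound 3 to compound 4 (within the scatter) removes both chloro groups, and the step of a number 6.9 percentage points lower from compound 2 to compound 4 (within the scatter) removes the methoxy group. Among these three compounds, the read-out therefore does not separate phenyl, 3,4-dichlorophenyl and 3-methoxyphenyl at this place. The step of a number 3.2 percentage points higher from compound 1 to compound 4 (within the scatter) adds that hydrogen in place of chloro on the other aryl group also stays within the scatter.

Still open, from the compounds shown here alone, is whether a group of another kind at this position, such as an amine or a carboxylic acid, would move the read-out beyond the scatter. Also open, going by these compounds, is how these compounds behave at any other concentration. No measured evidence accounts for these readings.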